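The compounds below may be only part of what the source reports. "The series", "measured", "known", "first", "only" and "open" are said of these compounds alone.

Measured in an ADME assay on HEK293 cells (Homo sapiens) for inhibition, read by MTT assay, with a stated time of 2 days; on this read-out lower numbers stand for stronger inhibition and higher numbers for weaker inhibition:
compound 1, `COc1ccc(/C=C/c2ccccc2O)cc1` — 21 ug/mL
compound 2, `Nc1ccc(/C=C/c2ccccc2O)cc1` — 21.4 ug/mL
compound 3, `Nc1ccc(/C=C/c2cccc(O)c2)cc1` — 25 ug/mL

The three numbers lie within the usual scatter of one another, so no order among compound 1, compound 2 and compound 3 is claimed. Compound 2 and compound 1 share a core and differ in one place: methoxy in place of amino on an aromatic carbon. That change gave a 1.0-fold lower number from compound 2 to compound 1 (0.01 log units; within the scatter). Compound 3 and compound 2 are built from the same atoms joined differently; the difference between the two cores is not broken down here.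

Compound 4, `COc1ccc(/C=C/c2cccc(O)c2)cc1`, remains to be measured in this assay. It stands to compound 3 as compound 1 stands to compound 2: methoxy in place of amino on an aromatic carbon. The place is described in the same words in both cases, so this is the same change made on the core of compound 3. Going by the values given here, the single earlier instance, from compound 2 to compound 1, was a 1.0-fold lower number from compound 2 to compound 1 (0.01 log units; within the scatter), and that is all the expectation rests on. The expected step is therefore no change at the digits printed from compound 3 to compound 4 (within the scatter). Compound 4 is estimated at 25 ug/mL, with a likely span from 14 ug/mL to 45 ug/mL.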

Compound 4, half-maximal inhibitory concentration: 24 ug/mL
Estimate against measurement, compound 4: 1.0-fold (0.02 log units) above; the range from low to high includes it.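

In this assay methoxy in place of amino on an aromatic carbon gave a 1.0-fold lower number from compound 3 to compound 4 (0.02 log units; within the scatter) and so reads the same as the earlier instance on the core of compound 2: the same change on two cores in this assay, a 1.0-fold lower number (0.01 log units; within the scatter) from compound 2 to compound 1 and a 1.0-fold lower number (0.02 log units; within the scatter) from compound 3 to compound 4, 1.0-fold (0.01 log units) apart, within the scatter of two such steps.
This shows that, on these two cores, the replacement carries over with no step beyond the scatter, so either group can stand at this place in the series without a resolved difference in this read-out. It does not show a general rule, since two cores built from the same atoms joined differently are a narrow test, and a step within the scatter cannot separate a small real effect from none.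

Open, as far as these compounds go, is how other groups at this place would read on either core, for example ethoxy, a longer alkoxy chain, dimethylamino or a chlorine atom. Also open, from the compounds shown here alone, is whether the same holds on a core without the hydroxyl group, and in any read-out other than this assay.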